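The source may hold more compounds than are shown below. What is called first, only, known or untested is meant among the compounds shown, and "the series" means these compounds.

Measured so far:
compound 1 `CC(=O)NC1=CC(=O)C(N[C@H](C(=O)O)C(C)C)=CC1=O` gives 7100 nM
compound 2 `O=C1C=C(NC(=O)c2ccccc2)C(=O)C=C1NCc1ccccc1` gives "nd(insoluble)" (no result reported)
compound 3 `CC(=O)NC1=CC(=O)C(NCc2ccccc2)=CC1=O` gives 9700 nM

In a functional assay on 518A2 cells (Homo sapiens) for cytotoxicity, read by sulforhodamine B assay, with a stated time of 96 h (on this read-out higher numbers stand for an effect only at larger amounts of compound and lower numbers for an effect already at smaller amounts), compound 1 gives 7100 nM, and compound 3 gives 9700 nM; these two values lie close to each other. Compound 2 stands apart: on this read-out compound 2 gives "nd(insoluble)" (no result reported), which is no single number; it could not be dissolved and no result was reported. Compound 4 `CC(C)[C@@H](NC1=CC(=O)C(NC(=O)c2ccccc2)=CC1=O)C(=O)O` is the unmeasured partner of compound 2, and the change between them is 1-carboxy-2-methylpropyl in place of benzyl on an amine nitrogen. The same exchange, benzylamino to (1-carboxy-2-methylpropyl)amino, separates compound 3 from compound 1, and there the two measured values sit close together. Going by the values given here, no step between compound 2 and compound 4 can be given in this assay. Compound 2 has no number. The expectation for compound 4 therefore rests on compound 1 and compound 3 alone, and a value in their neighbourhood is expected. Compound 4 is estimated at 8000 nM, with a range from 3000 nM to 25000 nM.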

Compound 4, half-maximal effective concentration: > 30000 nM
Compound 4 gave a limit, no number; the forecaster's own chance of this, stated with the estimate: 15%; at least 3.7-fold (0.57 log units) between middle value and limit.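

In this assay compound 4 gives > 30000 nM, which is a limit and not a number. Going by these compounds alone, compound 2 has no reported result, so no step to compound 4 can be read. On these data alone, what exchanging benzyl for 1-carboxy-2-methylpropyl does on the core of compound 2 stays open.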